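Chloro in place of hydrogen on compound 2

A few compounds are considered here, and "the series" means these few. Any claim that something is new, unique, unknown or untested is made for them only; others in the source may bear on it.

Compound 1 `CCOC(=O)c1nn(-c2ccc(Cl)cc2)c(-c2ccc(F)cc2)c1CNC(C)(C)C` gives 24700 nM; > 537000 nM (2 entries) in an ADME assay on HaCaT cells (Homo sapiens) for inhibition, read by sulforhodamine B assay, with a stated time of 48 h; on this read-out lower numbers stand for stronger inhibition of growth and higher numbers for weaker inhibition of growth. Compound 2 `CC(C)(C)NCc1c(C(=O)O)nn(-c2ccccc2)c1-c1ccc(F)cc1` gives > 680000 nM in this assay, which is a limit and not a number. Compound 3 `CC(C)(C)NCc1c(C(=O)O)nn(-c2ccc(Cl)cc2)c1-c1ccc(F)cc1` differs from compound 2 by a phenyl to 4-chlorophenyl change, chloro in place of hydrogen on an aromatic carbon. Among the measured compounds shown here, no measured step isolates this change. The expected step of an at least 1.3-fold lower number from compound 2 to compound 3 (0.13 log units; that floor lies within the scatter) is small, within the scatter or slightly toward stronger inhibition. Compound 3 is expected near 500000 nM, with an estimated range of 150000 nM to 1000000 nM.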

Compound 3, concentration for 50% growth inhibition: 28700 nM
Compound 3: the middle estimate sits 17-fold (1.24 log units) above what was measured; measured number outside the range, below it.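

Swapping phenyl for 4-chlorophenyl gives an at least 23-fold lower number from compound 2 to compound 3 (1.37 log units; beyond the scatter) in this assay, the first step in this series that can be read at all. Compound 2 gives > 680000 nM, which is a limit. A single chlorine atom, on an aromatic carbon para to a large group, is thus enough to bring this carboxylic acid to a measurable number of growth inhibition.

On these data alone, whether bromo, fluoro or methoxy at this position would give a similar step stays open. So does the true size of this step, since only its lower bound is known.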